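A few compounds are considered here, and "the series" means these few. Any claim that something is new, unique, unknown or untested is made for them only; others in the source may bear on it.

Three compounds of the series have been run in an ADME assay on HepG2 cells (Homo sapiens) for cytotoxicity, read by luminescence, CellTiter-Glo and ATP content, with a stated time of 72 h; a higher number here means that more compound is needed for the effect, a lower number that less compound is needed. Compound 1 `COc1cccc(CNCCCNc2ccnc3cc(Oc4ccc(Cl)cc4)ccc23)c1O` gives 5700 nM there; compound 2 `COc1ccc(-c2ccc3c(NCCCNCc4cccc(OC)c4O)ccnc3c2)cc1` gives 1600 nM; compound 3 `COc1cccc(CNCCCNc2ccnc3cc(-c4ccc(C(C)(C)C)cc4)ccc23)c1O` gives 690 nM. Compound 3 thus stands lowest of the three, with a 2.3-fold lower number from compound 2 to compound 3 (0.37 log units; beyond the scatter) and an 8.3-fold lower number from compound 1 to compound 3 (0.92 log units; beyond the scatter). Compound 4 `COc1ccccc1Oc1ccc2c(NCCCNCc3cccc(OC)c3O)ccnc2c1` is not yet measured in this assay. Its change from compound 3: 2-methoxyphenoxy in place of 4-(tert-butyl)phenyl on an aromatic carbon. Within the data shown here, the steps that bear on it are a 3.6-fold lower number from compound 1 to compound 2 (0.55 log units; beyond the scatter) and an 8.3-fold lower number from compound 1 to compound 3 (0.92 log units; beyond the scatter): compound 1, which carries the 4-chlorophenoxy group, gives the highest number, and both compounds without that group sit lower. Compound 4 carries the 2-methoxyphenoxy group, so a higher number beyond the scatter is expected, near a 5.1-fold higher number from compound 3 to compound 4 (0.71 log units; beyond the scatter). For compound 4 the estimate in this assay is 3500 nM, range 1200 nM to 10000 nM.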

Compound 4, half-maximal effective concentration in the HepG2 assay: 11200 nM
Compound 4: middle estimate off by 3.2-fold (0.51 log units), on the low side, and the stated range ends below it.
By their numbers in the HepG2 assay, from the lowest: compound 3; then compound 2; then compounds 1 and 4 (each within the scatter of the next).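

In the HepG2 assay the 2-methoxyphenoxy group gives a 16-fold higher number from compound 3 to compound 4 (1.21 log units; beyond the scatter) and a 7.0-fold higher number from compound 2 to compound 4 (0.85 log units; beyond the scatter), while a 2.0-fold higher number from compound 1 to compound 4 (0.29 log units; within the scatter), so the high number is not peculiar to 4-chlorophenoxy: among these four, both phenoxy compounds, compound 1 and compound 4, sit above both phenyl compounds, compound 2 and compound 3, and none goes against this. In a physicochemical assay for acid dissociation, compound 3 gives 9.47 and compound 4 gives 9.28, with a number 0.19 log units lower from compound 3 to compound 4 (within the scatter). Nothing shown bears on the cause of the gap between phenoxy and phenyl compounds.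

Open, as far as these compounds go, is whether unsubstituted phenoxy, or a phenyl ring carrying an amine or a carboxylic acid, follows the same split at this position.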